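Compound 3 to compound 4: chloro to trifluoromethyl

The compounds below may be only part of what the source reports. "The series", "measured", "known", "first", "only" and "open" are said of these compounds alone.

Of the compounds shown here, three have been tested so far in an ADME assay on MDCK cells (Canis lupus familiaris) for cytotoxicity (a higher number here means that more compound is tolerated, a lower number that less compound is tolerated), and none has yet given a number. Compound 1 (`CC(=O)Nc1ccc2oc(-c3ccnc(C(=O)N4CCC5(CC4)CCN(C(c4ccccc4)c4nnn(C)n4)CC5)c3)nc2c1`) gives > 50000 nM, which is a limit of the assay. Compound 2 (`CC(=O)Nc1ccc2oc(-c3ccnc(C(=O)N4CCN([C@@H](c5ccc(F)cc5)c5nnn(C)n5)CC4)c3)nc2c1`) gives > 200000 nM, also a limit. Compound 3 (`CC(=O)Nc1ccc2oc(-c3ccnc(C(=O)N4CCN(C(c5ccc(Cl)cc5)c5nnn(C)n5)CC4)c3)nc2c1`) gives > 50000 nM, again a limit, so its position in this assay is known only as a limit.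

Compound 4 (`CC(=O)Nc1ccc2oc(-c3ccnc(C(=O)N4CCN(C(c5ccc(C(F)(F)F)cc5)c5nnn(C)n5)CC4)c3)nc2c1`) has trifluoromethyl in place of chloro on an aromatic carbon, para to a large group: trifluoromethyl in place of chloro on an aromatic carbon. Going by the values given here, no measured pair isolates a single change, so the size of this step cannot be read from earlier data. No change beyond the usual scatter is expected, and the estimated step is a number no higher from compound 3 to compound 4 (the limit leaves the size open). This expectation rests on the limit of compound 3, > 50000 nM. Another limit rather than a number is the likeliest report. The estimate for compound 4 is 50000 nM, with an expected range of 20000 nM to 200000 nM.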

Compound 4, half-maximal cytotoxic concentration: > 50000 nM
Compound 4: a limit, no number (the forecaster's own chance of this, stated with the estimate: 85%); the middle value sits exactly at the limit.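

Compound 3 gives > 50000 nM in this assay, a limit. Compound 4 gives > 50000 nM, also a limit, so the step from chloro to trifluoromethyl cannot be read. Whether these two compounds differ at all stays open: none of the compounds shown has given a number.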